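Furan for thiophene on a pyridine core: second pairing

The compounds below may be only part of what the source reports. "The series", "measured", "known", "first", "only" and "open" are said of these compounds alone.

Measured so far in a functional assay on HeLa cells (Homo sapiens) for cytotoxicity, read by ELISA, with a stated time of 2 days; on this read-out lower numbers stand for stronger inhibition and higher numbers for weaker inhibition:
- compound 1, `Oc1ccc(-c2cc(-c3ccccc3)cc(-c3ccsc3)n2)cc1`: 17300 nM
- compound 2, `Oc1ccc(-c2cc(-c3ccccc3)cc(-c3ccco3)n2)cc1`: 10900 nM
- compound 3, `Oc1cccc(-c2cc(-c3ccccc3)nc(-c3ccsc3)c2)c1`: 14900 nM

Compound 1 and compound 2 differ in one place, (furan-2-yl in place of thiophen-3-yl on an aromatic carbon). That change gave a 1.6-fold lower number from compound 1 to compound 2 (0.20 log units; within the scatter). Compound 3 is built from the same atoms as compound 1, joined differently; how the two cores differ is not broken down here. Its value sits close to those of compound 1 and compound 2, with all three numbers within the scatter of one another, so no order among them can be stated.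

Compound 4, `Oc1cccc(-c2cc(-c3ccccc3)nc(-c3ccco3)c2)c1`, has not yet been measured. It stands to compound 3 as compound 2 stands to compound 1: furan-2-yl in place of thiophen-3-yl on an aromatic carbon. The surroundings are not identical, since the place is meta to a 3-hydroxyphenyl group here and meta to a 4-hydroxyphenyl group in the first pair, so this is the same kind of change rather than the same change.

The step expected from compound 3 to compound 4 in this assay is a 1.6-fold lower number from compound 3 to compound 4 (0.20 log units; within the scatter), set beside the earlier one. This expectation rests on compound 1 and compound 2, because a 1.6-fold lower number from compound 1 to compound 2 (0.20 log units; within the scatter) was small and within the scatter. Compound 4 is therefore estimated at 9500 nM, with a range from 5000 nM to 18000 nM.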

Compound 4, half-maximal inhibitory concentration: 10900 nM
Compound 4: the middle estimate sits 1.1-fold (0.06 log units) below what was measured; the measured number falls inside the stated range.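

In this assay, furan-2-yl in place of thiophen-3-yl on the second core gave a 1.4-fold lower number from compound 3 to compound 4 (0.14 log units; within the scatter). Set beside the first pairing, the two steps cannot be told apart: the same change on two cores in this assay, a 1.6-fold lower number (0.20 log units; within the scatter) from compound 1 to compound 2 and a 1.4-fold lower number (0.14 log units; within the scatter) from compound 3 to compound 4, 1.2-fold (0.06 log units) apart, within the scatter of two such steps. This shows that the change carried from one core to the other without producing a step that stands clear of the scatter, but it does not show that furan-2-yl and thiophen-3-yl differ in this assay on either core, and two steps this small say little about how a larger effect would carry between these cores.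

The compounds shown leave open whether a group of another kind at the place next to the ring nitrogen, such as an aminomethyl group, a carboxylic acid or a longer alkyl chain, would give a step beyond the scatter. They also leave open whether a methoxy group in place of the hydroxyl of the hydroxyphenyl group would change the picture on either core.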